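This account rests on a few compounds, and the source may have more. Where it says the series, first, only, none or still open, it means among the compounds named here.

Compound 1 `O=C(NCc1ccc(OCc2ccccc2)cc1)n1cccn1` and compound 2 `N#Cc1cnn(C(=O)NCc2ccc(OCc3ccccc3)cc2)c1` share one core, and compound 3 `CN(CCN(C)C(c1ccc(OCc2ccccc2)cc1)c1ccc(OCc2ccccc2)cc1)C(=O)n1cccn1` and compound 4 `CN(CCN(C)C(c1ccc(OCc2ccccc2)cc1)c1ccc(OCc2ccccc2)cc1)C(=O)n1cc(C#N)cn1` share another; the difference between the two cores is not broken down here. In an assay on membranes from brain for binding affinity to Monoglyceride lipase (Mus musculus), read by fluorescence, with stated times of 1 h and 30 min (on this read-out higher numbers stand for weaker inhibition and lower numbers for stronger inhibition), compound 1 gives 900 nM. In this assay compound 2 gives 100 nM. The change between them, (cyano in place of hydrogen on an aromatic carbon), made a 9.0-fold lower number from compound 1 to compound 2 (0.95 log units; beyond the scatter). In this assay compound 3 gives only a limit, > 1000000 nM, namely (the limit of > 1000000 nM in this assay, at which 1 of the 3 values shown sits). Compound 4 carries the same change on the second core, (cyano in place of hydrogen on an aromatic carbon), and its place matches the earlier one word for word. Since compound 3 sits at a limit, the size of the step from compound 3 to compound 4 cannot be read from a number, and the estimate leans on the change measured from compound 1 to compound 2 as a 9.0-fold lower number from compound 1 to compound 2 (0.95 log units; beyond the scatter). Compound 4 is therefore estimated at 500000 nM, within 100000 nM to 2000000 nM, which would mean an expected at least 2.0-fold lower number from compound 3 to compound 4 (0.30 log units; that floor lies within the scatter).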

Compound 4, half-maximal inhibitory concentration: 32000 nM
Estimate against measurement, compound 4: 16-fold (1.19 log units) above, outside the stated range (below it).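

In this assay, cyano in place of hydrogen on the pyrazole's aromatic carbon lowered the number on both cores, and on the second core the result is an at least 31-fold lower number from compound 3 to compound 4 (1.49 log units; beyond the scatter). As far as these compounds go, the steps on the two cores differ in size: the same change on two cores in this assay, a 9.0-fold lower number (0.95 log units; beyond the scatter) from compound 1 to compound 2 and an at least 31-fold lower number (1.49 log units; beyond the scatter) from compound 3 to compound 4, at least 3.4-fold (0.54 log units) apart, beyond the scatter of two such steps Compound 3 stands only at a limit, > 1000000 nM, so the direction of the change carries over to the second core, while its true size there remains unknown and no single size can be given for both cores.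

The compounds shown leave open how a group other than cyano, such as an amine or a carboxylic acid, would behave at the same place. They also leave open whether the change would act alike on a core with a longer chain.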